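The compounds below may be only part of what the source reports. "The series", "measured", "known", "first", "only" and "open" are said of these compounds alone.

Working notes on the series. Compound 1 `COc1ccc(CS(=O)(=O)/C=C/c2ccccc2OC)cc1` carries the shared core; in a functional assay on DLD-1 cells (Homo sapiens) for antiproliferative activity, read by trypan blue exclusion (on this read-out lower numbers stand for stronger inhibition and higher numbers for weaker inhibition), compound 1 gives 7500 nM. Compound 2 `COc1ccc(CS(=O)(=O)/C=C/c2ccc(OC)cc2OC)cc1` adds one group to that core: methoxy in place of hydrogen on an aromatic carbon. In this assay compound 2 reaches only a limit, > 20000 nM. The step of an at least 2.6-fold higher number from compound 1 to compound 2 (0.42 log units; beyond the scatter) therefore rests on (the limit of > 20000 nM in this assay, at which 2 of the 3 values shown sit). Compound 3 `COc1ccc(CS(=O)(=O)/C=C/c2cc(OC)cc(OC)c2)cc1` differs from compound 1 in more than one place; the difference between the two cores is not broken down here. In this assay compound 3 likewise gives only a limit, > 20000 nM. Compound 4 `COc1ccc(CS(=O)(=O)/C=C/c2cc(OC)c(OC)c(OC)c2)cc1` is not yet measured; it differs from compound 3 by the same kind of change as compound 2 from compound 1: methoxy in place of hydrogen on an aromatic carbon. The surroundings are not identical: in compound 2 the entering group is meta to a methoxy group, in compound 4 it is ortho to two methoxy groups, and in both it is para to a large group. Since compound 3 already sits at the limit of > 20000 nM in this assay, at which 2 of the 3 values shown sit, and the earlier addition gave an at least 2.6-fold higher number from compound 1 to compound 2 (0.42 log units; beyond the scatter), compound 4 is expected to remain at the limit, an estimated step that the limit leaves unreadable from compound 3 to compound 4. The estimate for compound 4 is 30000 nM, between 12000 nM and 100000 nM.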

Compound 4, half-maximal inhibitory concentration: > 20000 nM
Compound 4 ended at the assay's limit; the forecaster's own chance of this, stated with the estimate: 85%; the middle value lies beyond the limit too.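

No new step can be read from compound 3 to compound 4, since both end at a limit in this assay and the size of the change stays unreadable: the limit of > 20000 nM in this assay, at which 3 of the 4 values shown sit.

The compounds shown leave open where compound 2, compound 3 and compound 4 actually stand relative to one another, and whether the methoxy entering compound 3 changes antiproliferative activity at all.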